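Dimethoxyphenyl hydrazone in a paw-edema series

The source may hold more compounds than are shown below. What is called first, only, known or untested is meant among the compounds shown, and "the series" means these compounds.

Three compounds have been measured in a functional assay on the whole organism (strain Wistar) for inhibition, with Rattus norvegicus as the target, read by paw edema, with a stated time of 2 h, at a dose of 10 mg/kg by the intraperitoneal route; a lower number here means less inhibition, a higher number more inhibition at the dose given (going by the name of the read-out):
Compound 1, `O=C(N/N=C/c1cccc(F)c1)c1cccnc1Nc1cccc(C(F)(F)F)c1`, gives 52.8%.
Compound 2, `O=C(N/N=C/c1ccc(Cl)cc1)c1cccnc1Nc1cccc(C(F)(F)F)c1`, gives 52.8%.
Compound 3, `COc1cccc(/C=N/NC(=O)c2cccnc2Nc2cccc(C(F)(F)F)c2)c1`, gives 49.7%.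

Compound 2 stands level with compound 1, the two together the highest of the three numbers; its nearest neighbour is compound 1, with no change at the digits printed from compound 1 to compound 2 (within the scatter), and its furthest is compound 3, with a number 3.1 percentage points lower from compound 2 to compound 3 (within the scatter). Among the compounds with values here, compound 4, `COc1ccc(/C=N/NC(=O)c2cccnc2Nc2cccc(C(F)(F)F)c2)c(OC)c1`, is not yet measured; it differs from compound 2 thus: 2,4-dimethoxyphenyl in place of 4-chlorophenyl on a carbon with a double bond to nitrogen The steps that bear on this change are those placing a methoxy group on the aryl ring, a number 3.1 percentage points lower from compound 1 to compound 3 (within the scatter) and a number 3.1 percentage points lower from compound 2 to compound 3 (within the scatter), both within the scatter. A step of a number 2.8 percentage points lower from compound 2 to compound 4 (within the scatter) is therefore expected, with no direction beyond the scatter. Compound 4 is estimated at 50%, between 38% and 60%.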

Compound 4, a percentage reported as inhibition, in the whole organism at one dose (the size of the read-out at that dose, not a potency): 44.7%
Estimate against measurement, compound 4: 5.3 percentage points above, and the stated range covers the measured number.
By their numbers in this assay, from the lowest: compounds 4, 3, 1 and 2 (each within the scatter of the next).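

In this assay, the 2,4-dimethoxyphenyl group on the carbon with a double bond to nitrogen stays within the scatter of all three earlier aryl groups: a number 8.1 percentage points lower from compound 2 to compound 4 (within the scatter), a number 8.1 percentage points lower from compound 1 to compound 4 (within the scatter) and a number 5 percentage points lower from compound 3 to compound 4 (within the scatter). This position therefore accepts a second methoxy group, and with it the larger group of the set, without any step beyond the scatter. No measurement at hand explains these numbers. Going by these compounds, what an amine or a carboxylic acid on this aryl ring would do remains open, as does replacing the ring with a simple alkyl chain.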